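Aryl amide swaps on a shared core: flat numbers so far

This account rests on a few compounds, and the source may have more. Where it says the series, first, only, none or still open, it means among the compounds named here.

Measured to date in a functional assay on HL-60 cells (Homo sapiens) for antiproliferative activity, with a stated time of 24 h; a higher number here means a weaker inhibitor, a lower number a stronger inhibitor:
- compound 1, `NC(=O)c1c(NC(=O)c2ccc(C(F)(F)F)cc2)sc2c1CCN(Cc1c(Cl)cccc1Cl)C2`: compound 1 gives 10600 nM
- compound 2, `Cc1ccc(C(=O)Nc2sc3c(c2C(N)=O)CCN(Cc2c(Cl)cccc2Cl)C3)cc1`: compound 2 gives 10000 nM
- compound 3, `NC(=O)c1c(NC(=O)c2ccccc2F)sc2c1CCN(Cc1c(Cl)cccc1Cl)C2`: compound 3 gives 10300 nM

Compound 3 stands second highest of the three numbers; its nearest neighbour is compound 1 and its furthest compound 2, and both gaps lie within the scatter. The next compound, compound 4, `NC(=O)c1c(NC(=O)c2cccc([N+](=O)[O-])c2)sc2c1CCN(Cc1c(Cl)cccc1Cl)C2`, differs from compound 3 in one place: 3-nitrophenyl in place of 2-fluorophenyl on a carbonyl carbon.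

Among the compounds with values here, no measured step swaps in a nitro-bearing ring, so the nearest guides are the two earlier swaps on the same carbonyl carbon: a 1.0-fold lower number from compound 1 to compound 3 (0.01 log units; within the scatter) and a 1.0-fold higher number from compound 2 to compound 3 (0.01 log units; within the scatter). The step of a 1.1-fold lower number from compound 1 to compound 2 (0.03 log units; within the scatter), a change within the aryl group only, is equally flat. Three different aryl groups on this carbonyl carbon have thus given numbers that cannot be told apart, and nothing among them points to a direction for a fourth. The working expectation for compound 4 in this assay is therefore no step beyond the scatter, that is a 1.0-fold lower number from compound 3 to compound 4 (0.01 log units; within the scatter).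

Compound 4 is accordingly estimated at 10000 nM, with a range from 4000 nM to 25000 nM.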

Compound 4, half-maximal inhibitory concentration: 18400 nM
For compound 4 the middle estimate is 1.8-fold (0.26 log units) below the measured one, and the stated range covers the measured number.
By their numbers in this assay, from the lowest: compounds 2, 3, 1 and 4 (each within the scatter of the next).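

Working from a 1.8-fold higher number from compound 3 to compound 4 (0.25 log units; within the scatter) and a 1.8-fold higher number from compound 2 to compound 4 (0.26 log units; within the scatter) as well as a 1.7-fold higher number from compound 1 to compound 4 (0.24 log units; within the scatter) in this assay, 3-nitrophenyl on this carbonyl carbon cannot be told apart from any of the three earlier aryl groups. The change adds a group counting 2 hydrogen-bond acceptors where 2-fluorophenyl counts 0, and this difference gives no step beyond the scatter, so the flat picture now covers four aryl groups with different substituents, all on the same shared core. No measurement at hand addresses why these numbers lie so close together.

The compounds shown leave open whether any group on this carbonyl carbon can move the number in this assay beyond the scatter, for example a phenyl ring carrying an amine or a carboxylic acid, or a longer alkyl chain in place of the aromatic ring. They also leave open how much the number depends on the rest of the molecule, since the primary amide and the dichlorophenylmethyl group stay the same throughout these four compounds.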